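A few compounds are considered here, and "the series" means these few. Any claim that something is new, unique, unknown or untested is made for them only; others in the source may bear on it.

Measured compounds in an ADME assay on the whole organism (strain FVB) for pharmacokinetics, with Mus musculus as the target, read by LC-MS, at a dose of 30 mg/kg by the oral route; a lower number here means less compound in the circulation, a higher number more compound in the circulation at the dose given:
compound 1 `CC(C)(O)CN1CCC(Oc2ccc([C@H]3CC[C@]4(CC3)OOC3(O4)C4CC5CC(C4)CC3C5)cc2)CC1`; compound 1 gives 1810 nM
compound 2 `N[C@H]1CC[C@@H](Oc2ccc([C@H]3CC[C@]4(CC3)OOC3(O4)C4CC5CC(C4)CC3C5)cc2)CC1`; compound 2 gives 1170 nM
compound 3 `c1cc([C@H]2CC[C@]3(CC2)OOC2(O3)C3CC4CC(C3)CC2C4)ccc1OCCC1CCNCC1`; compound 3 gives 1190 nM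

Compound 2 shows the lowest of the three numbers in this assay, but the spread is small: the step of a 1.5-fold lower number from compound 1 to compound 2 (0.19 log units; within the scatter) and the step of a 1.0-fold higher number from compound 2 to compound 3 (0.01 log units; within the scatter) both lie within the scatter, and so does a 1.5-fold lower number from compound 1 to compound 3 (0.18 log units; within the scatter). On these three numbers, which differ only in the group on the oxygen on the aromatic ring, nothing can be told apart.

Compound 4 `O[C@H]1CC[C@H](NCCCOc2ccc([C@H]3CC[C@]4(CC3)OOC3(O4)C4CC5CC(C4)CC3C5)cc2)CC1` is the next member, not yet measured. The change from compound 2 is 3-((4-hydroxycyclohexyl)amino)propyl in place of 4-aminocyclohexyl on an oxygen on an aromatic ring.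

The two steps that bear on this change are those that swap the group on the same oxygen, from compound 1 to compound 2 and from compound 2 to compound 3. Each of those was within the scatter. There is nothing in the series to suggest that a further exchange at this position should move the maximal plasma concentration beyond the scatter, so the step of a 1.1-fold higher number from compound 2 to compound 4 (0.05 log units; within the scatter) is expected to stay within it.

Compound 4 is therefore estimated at 1300 nM, with a likely range from 500 nM to 3400 nM.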

Compound 4, maximal plasma concentration: 721 nM
Beside the measured number, compound 4's estimate is 1.8-fold (0.26 log units) above it, within the range that was stated.
By their numbers in this assay, from the lowest: compounds 4, 2, 3 and 1 (each within the scatter of the next, the first and the last beyond it).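

In this assay, going by these compounds alone, the 3-((4-hydroxycyclohexyl)amino)propyl group on the oxygen gives the first step that lies beyond the scatter, a 2.5-fold lower number from compound 1 to compound 4 (0.40 log units; beyond the scatter), although the size of that step is modest. The same group stays within the scatter against the two smaller changes at this position, with a 1.6-fold lower number from compound 2 to compound 4 (0.21 log units; within the scatter) and a 1.7-fold lower number from compound 3 to compound 4 (0.22 log units; within the scatter), so compounds 2, 3 and 4 cannot be told apart, and only compound 1 and compound 4 separate. No measured evidence accounts for this separation.

Compound 4 differs from compound 1 in both the chain on the oxygen and the ring at its end, so these compounds leave open which of the two parts carries the step. Going by these compounds, the effect on maximal plasma concentration of the 4-hydroxycyclohexyl amine on an ethyl chain instead of a propyl chain also remains open, as does the effect of a morpholine or a carboxylic acid on the same oxygen.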